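A few compounds are considered here, and "the series" means these few. Any claim that something is new, unique, unknown or untested is made for them only; others in the source may bear on it.

Measured in a functional assay with Neuronal acetylcholine receptor; alpha3/beta4 (Homo sapiens) as the target (a lower number here means a stronger inhibitor, a higher number a weaker inhibitor), so far:

compound 1 `CCC1CC(=O)N(c2ccccc2C(=O)OCC2CCCN(CCCc3ccccc3)C2)C1=O` gives 4500 nM
compound 2 `CCCCC1CC(=O)N(c2ccccc2C(=O)OCC2CCCN(CCCc3ccccc3)C2)C1=O` gives 1500 nM
compound 3 `O=C(OCC1CCCN(CCCc2ccccc2)C1)c1ccccc1F` gives 5200 nM

Among these three numbers compound 1 stands second highest. For the measured compounds named here, its neighbour is compound 3, a step of a 1.2-fold higher number from compound 1 to compound 3 (0.06 log units; within the scatter) that sits within the scatter; the one step beyond the scatter is a 3.0-fold lower number from compound 1 to compound 2 (0.48 log units; beyond the scatter).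

Compound 4 `O=C(OCC1CCCN(CCCc2ccccc2)C1)c1ccccc1-c1ccccc1` has not yet been measured. Against compound 1 the change is a group of 6 heavy atoms (6 carbon; one six-membered aromatic ring of carbon only) in place of a group of 9 heavy atoms (6 carbon, 1 nitrogen, 2 oxygen; one five-membered non-aromatic ring with 1 hetero atom), on an aromatic carbon, placed ortho to a large group.

Two measured steps speak to this change. The first, a 1.2-fold higher number from compound 1 to compound 3 (0.06 log units; within the scatter), shows that taking the whole group away at this aromatic carbon and leaving only a fluorine atom makes no difference beyond the scatter. The second, a 3.5-fold higher number from compound 2 to compound 3 (0.54 log units; beyond the scatter), shows that the bulkier of the two ring groups gives a modestly lower number than fluorine alone. Phenyl falls between these cases in what it brings to the same position, so the expectation is a small step at most, perhaps a slightly lower number, but nothing clearly beyond the scatter.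

Compound 4 is therefore estimated at 3000 nM, with a range from 1000 nM to 9000 nM. This estimate means an expected step of a 1.5-fold lower number from compound 1 to compound 4 (0.18 log units; within the scatter).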

Compound 4, half-maximal inhibitory concentration: 1700 nM
For compound 4 the middle estimate is 1.8-fold (0.25 log units) above the measured one, and the stated range covers the measured number.
By their numbers in this assay, from the lowest: compounds 2 and 4 (each within the scatter of the next); then compounds 1 and 3 (each within the scatter of the next).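

In this assay, the direct exchange of fluoro for phenyl on this aromatic carbon gives a step beyond the scatter (a 3.1-fold lower number from compound 3 to compound 4 (0.49 log units; beyond the scatter)), showing that a group of carbon atoms alone can lower the number here. Replacing the ring group of compound 1 with phenyl also gives a step beyond the scatter (a 2.6-fold lower number from compound 1 to compound 4 (0.42 log units; beyond the scatter)), whereas replacing the larger ring group of compound 2 with phenyl stays within the scatter (a 1.1-fold higher number from compound 2 to compound 4 (0.05 log units; within the scatter)), so among these compounds, the nitrogen and oxygen atoms of those ring groups are not needed to reach a number this low. The data available give no reason for these differences.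

On these data alone, it remains open whether the lower number needs an aromatic ring at this carbon, since a cyclohexyl or a small methyl could behave differently, and whether a pyridine ring would match phenyl. As far as these compounds go, it is equally open how an amine or a carboxylic acid placed on the phenyl ring would shift the number, and whether these steps would hold with other groups elsewhere on the shared core.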